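The source may report more compounds than this note shows. Statements on the series, on what has been measured and on what is new or still open speak of the compounds shown alone.

Working notes on the series.

Of the compounds shown here, three have been measured in an assay on isolated protein for inhibition of serine/threonine-protein kinase Chk2 (Homo sapiens), read by mobility shift assay, tested at 30 uM; on this read-out lower numbers stand for less inhibition and higher numbers for more inhibition at the one concentration tested (going by the name of the read-out). Compound 1 `Nc1n[nH]c2cc(-c3cccnc3)[nH]c(=O)c12` gives 27%. Compound 2 `Cc1cc2c(c(N)nn2C)c(N2CCCCC2)n1` gives 4%. Compound 3 `CC(C)(C)c1cc2nn(-c3ccccc3)c(N)c2c(=O)[nH]1` gives 5%. On these three numbers compound 3 stands second highest; its nearest neighbour is compound 2, which lies within the scatter of it, and its furthest is compound 1, which lies beyond the scatter above it.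

Compound 4 `COc1ccc(-c2cc3nn(-c4ccccc4)c(N)c3c(=O)[nH]2)cc1` has not yet been measured. It differs from compound 3 in one place: 4-methoxyphenyl in place of tert-butyl on an aromatic carbon.

Going by the values given here, no step between measured compounds involving this change is available, so the expectation rests on what the three values show. Compound 1, which carries an aromatic ring at the corresponding part of its core, gives 27%, while compound 3 gives 5%; compound 1 differs from compound 3 in several other places as well, so this is only a loose pointer. A modest rise, a number 10 percentage points higher from compound 3 to compound 4 (within the scatter), is expected, of a size near the edge of the scatter rather than clearly beyond it. For compound 4 in this assay the estimate is 15%, within a range of 0% to 40%.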

Compound 4, a percentage reported as inhibition, at one concentration (the size of the read-out at that concentration, not a potency): -3%
Beside the measured number, compound 4's estimate is 18 percentage points above it, and the stated range ends above it.
By their numbers in this assay, from the lowest: compounds 4, 2 and 3 (each within the scatter of the next); then compound 1.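

In this assay, 4-methoxyphenyl in place of tert-butyl on this aromatic carbon gives a number 8 percentage points lower from compound 3 to compound 4 (within the scatter), so on this core the added aromatic ring and hydrogen-bond acceptor bring nothing that can be told from the scatter. Compound 3 gives 5% and compound 4 gives -3%, both close to zero at the one concentration tested, which leaves little room to see any drop at this position. Nothing measured on hand offers an explanation for this result.

Open, from the compounds shown here alone, is whether another group on this carbon, such as an amine, a carboxylic acid or a longer alkyl chain, would give a number beyond the scatter from compound 3. Also open, going by these compounds, is how either compound would read at any other concentration.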